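A few compounds are considered here, and "the series" means these few. Any claim that something is new, unique, unknown or untested is made for them only; others in the source may bear on it.

Measured so far in a functional assay on HCC827 cells (Homo sapiens) for antiproliferative activity, read by MTT assay, with a stated time of 72 h; a higher number here means a weaker inhibitor, a lower number a stronger inhibitor:

Compound 1 `CC(C)n1c(Sc2ccccc2)nc2cnc(Nc3ccc(N4CCN(C)CC4)cc3)nc21`: 290 nM
Compound 2 `CN(C)C1CCN(c2ccc(Nc3ncc4nc([S+]([O-])c5ccccc5)n(C5CCOCC5)c4n3)cc2)CC1`: 1290 nM

Compound 2 stands highest of these two numbers at 1290 nM and so is the weaker inhibitor, a gap from compound 1 that lies beyond the scatter. Compound 3 `CN(C)CCN(C)c1ccc(Nc2ncc3nc([S+]([O-])c4ccccc4)n(C4CCOCC4)c3n2)cc1` differs from compound 2 in one place: (2-(dimethylamino)ethyl)(methyl)amino in place of 4-(dimethylamino)piperidin-1-yl on an aromatic carbon. Within the data shown here, no measured pair shows this kind of change, so the expectation is loose: a step in this assay within the scatter, with no firm direction. The expected change is a 1.3-fold lower number from compound 2 to compound 3 (0.11 log units; within the scatter) and no more. For compound 3 the estimated value is 1000 nM with an expected range from 350 nM to 3000 nM in this test.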

Compound 3, half-maximal inhibitory concentration: 1330 nM
Beside the measured number, compound 3's estimate is 1.3-fold (0.12 log units) below it, and the stated range covers the measured number.
By their numbers in this assay, from the lowest: compound 1; then compounds 2 and 3 (each within the scatter of the next).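

In this assay, replacing the ring of 4-(dimethylamino)piperidin-1-yl with the open chain (2-(dimethylamino)ethyl)(methyl)amino gives a 1.0-fold higher number from compound 2 to compound 3 (0.01 log units; within the scatter). At this aromatic carbon, then, the ring can give way to the chain with no change that stands out from the scatter, at least on the core of compound 2. No measurement here explains why the two groups read alike. From the compounds shown here alone, whether morpholin-4-yl, which has oxygen in place of the dimethylamino nitrogen, would read the same remains open. So does the effect of a longer chain between the two nitrogens.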